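Removal of bromo across two benzofuran cores

The compounds below may be only part of what the source reports. "The series", "measured", "known", "first", "only" and "open" are said of these compounds alone.

Measured so far in an assay on cells for inhibition of Amine oxidase [flavin-containing] B (Homo sapiens), read by fluorescence and Amplex Red, with a stated time of 15 min; on this read-out higher numbers stand for weaker inhibition and lower numbers for stronger inhibition:
compound 1 `Cc1ccc2oc(-c3ccccc3Br)cc2c1`, 200 nM
compound 2 `Cc1cccc2cc(-c3cccc(Br)c3)oc12`, 3980 nM
compound 3 `Cc1ccc2oc(-c3ccccc3)cc2c1`, 880 nM

Compound 1 and compound 2 hold the same atoms joined differently; the difference between the two cores is not broken down here. Compound 2 gives the highest number of the three, and compound 3 stands nearer to it than compound 1 does.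

Within the core of compound 1 the change hydrogen in place of bromo on an aromatic carbon gave a 4.4-fold higher number from compound 1 to compound 3 (0.64 log units; beyond the scatter). Compound 4 `Cc1cccc2cc(-c3ccccc3)oc12` is not yet measured; it arises from compound 2 by hydrogen in place of bromo on an aromatic carbon, the same kind of change, though here the place is meta to a large group where before it was ortho to a large group. Among the compounds with values here, the expected step is a 3.0-fold higher number from compound 2 to compound 4 (0.48 log units; beyond the scatter), resting on the single earlier step of a 4.4-fold higher number from compound 1 to compound 3 (0.64 log units; beyond the scatter), with wider uncertainty since the place differs. Compound 4 is thus estimated at 12000 nM in this assay, between 4000 nM and 35000 nM.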

Compound 4, half-maximal inhibitory concentration: 10700 nM
Estimate against measurement, compound 4: 1.1-fold (0.05 log units) above; the measured number falls inside the stated range.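

Hydrogen in place of bromo again gives weaker inhibition in this assay, now with a 2.7-fold higher number from compound 2 to compound 4 (0.43 log units; beyond the scatter). The change carries from one core to the other in direction, and the two steps do not differ in size beyond what repeated measurement allows: the same change on two cores in this assay, a 4.4-fold higher number (0.64 log units; beyond the scatter) from compound 1 to compound 3 and a 2.7-fold higher number (0.43 log units; beyond the scatter) from compound 2 to compound 4, 1.6-fold (0.21 log units) apart, within the scatter of two such steps These two pairs do not separate the effect of the core from that of the place, since the bromo stands at a different place on the ring in each pair, and they say nothing about any third core.

Still open, on these data alone, is how other groups at these places, such as chloro, methoxy or an amine, would read on either core. Also open, as far as these compounds go, is whether bromo moved to the other place on each core would give a step of similar size.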